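A few compounds are considered here, and "the series" means these few. Any claim that something is new, unique, unknown or untested is made for them only; others in the source may bear on it.

Values in a functional assay on MCF7 cells (Homo sapiens) for antiproliferative activity, read by MTT assay, with a stated time of 48 h (on this read-out higher numbers stand for weaker inhibition and lower numbers for stronger inhibition), for the series
Compound 1 `COC(=O)/C(=C/c1ccccc1)CN1C(=O)[C@@H](OC)[C@H]1c1ccc(Cl)cc1` gives 15300 nM
Compound 2 `COC(=O)/C(=C/c1ccccc1)CN1C(=O)[C@@H](OC)[C@H]1c1ccccc1C(F)(F)F` has no result reported
Compound 3 `COC(=O)/C(=C/c1ccccc1)CN1C(=O)[C@@H](OC)[C@H]1c1ccccc1` gives 12900 nM

Compound 3 at 12900 nM stands within the scatter of compound 1 at 15300 nM and no order can be read between the two. Compound 2 offers no number for comparison.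

Next in these notes is compound 4 `COC(=O)/C(=C/c1ccccc1)CN1C(=O)[C@@H](OC)[C@H]1c1cccc([N+](=O)[O-])c1` with the core of compound 3 kept. The difference is nitro in place of hydrogen on an aromatic carbon and it reads as nitro in place of hydrogen on an aromatic carbon, meta to a large group, or phenyl to 3-nitrophenyl.

Going by the values given here, one measured step bears on this, a 1.2-fold lower number from compound 1 to compound 3 (0.07 log units; within the scatter) and it is also an exchange on an aromatic carbon. It concerns chloro and not nitro, and it is a single pair, so it gives only weak guidance. Among the compounds with values here, no step beyond the scatter is expected in this assay for this change, but nitro has no measured precedent, so the range is kept wide.

Compound 4 is estimated at 12000 nM with 5000 nM to 30000 nM as the expected range. This estimate means a 1.1-fold lower number from compound 3 to compound 4 (0.03 log units; within the scatter) as the expected step.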

Compound 4, half-maximal inhibitory concentration: 15000 nM
Beside the measured number, compound 4's estimate is 1.3-fold (0.10 log units) below it; low and high end bracket the measured number.
By their numbers in this assay, from the lowest: compounds 3, 4 and 1 (each within the scatter of the next).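

In this assay, nitro in place of hydrogen on an aromatic carbon, meta to a large group, gives a 1.2-fold higher number from compound 3 to compound 4 (0.07 log units; within the scatter) and so adds a group of 3 heavy atoms at this place without a step beyond the scatter. Read as 3-nitrophenyl in place of 4-chlorophenyl on a saturated ring carbon, the exchange gives a 1.0-fold lower number from compound 1 to compound 4 (0.01 log units; within the scatter) and also stays within the scatter, so the series now holds a second kind of group on the aromatic ring, at a different place from the chloro of compound 1, and compounds 1, 3 and 4 still cannot be ordered. Nothing at hand gives a reason why these exchanges leave the number within the scatter.

On these data alone, it remains open whether this flat reading extends to other groups on the aromatic ring, such as an amine or a carboxylic acid, or to nitro at other places on that ring. Also open, as far as these compounds go, is whether any exchange away from the aromatic ring, for instance a carboxylic acid in place of the methyl ester, would give a step beyond the scatter in this assay.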